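Methyl for acetyl on sulfur in compound 4

A few compounds are considered here, and "the series" means these few. Any claim that something is new, unique, unknown or untested is made for them only; others in the source may bear on it.

In a functional assay on ASPC1 cells (Homo sapiens) for inhibition, read by MTT assay, with a stated time of 96 h (a lower number here means a stronger inhibitor of growth, a higher number a weaker inhibitor of growth), compound 1 (`C=CCOC(=O)SCCCCCCNC(=O)c1cc(-c2ccncc2)n[nH]1`) gives 27500 nM as a measured number. Compound 2 (`CCC(=O)SCCCCCCNC(=O)c1cc(-c2ccncc2)n[nH]1`) gives only a limit, > 50000 nM and no number. Compound 3 (`CC(=O)SCCCCCCNC(=O)c1cc(-c2ccncc2)n[nH]1`) also gives only a limit, > 50000 nM and no number. Its place is the limit of > 50000 nM in this assay, at which 2 of the 3 values shown sit, and no finer reading exists.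

Compound 4 (`CSCCCCCCNC(=O)c1cc(-c2ccncc2)n[nH]1`) has methyl in place of acetyl on a sulfur. For the measured compounds named here, no measured step removes that carbonyl. The nearest are an at least 1.8-fold higher number from compound 1 to compound 2 (0.25 log units; that floor lies within the scatter) and an at least 1.8-fold higher number from compound 1 to compound 3 (0.25 log units; that floor lies within the scatter) and neither floor clears the scatter, while a step that the two limits leave unreadable from compound 2 to compound 3 adds nothing. No step beyond the scatter is expected in this assay and a further limit is likely. The expected change is a step that the limit leaves unreadable from compound 3 to compound 4 as an estimate. Compound 4 is expected at 60000 nM with an estimated range from 30000 nM to 120000 nM as its ends.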

Compound 4, concentration for 50% growth inhibition: > 50000 nM
Compound 4: only a limit was reported; the forecaster's own chance of this, stated with the estimate: 75%; the middle value does not contradict the limit.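

With methylsulfanyl in place of acetylsulfanyl, the carbonyl on the sulfur is gone, yet in this assay compound 4 still reports only a limit, which puts it with compound 2 and compound 3: the limit of > 50000 nM in this assay, at which 3 of the 4 values shown sit.

The steps among these three compounds cannot be read, and the one readable step, an at least 1.8-fold higher number from compound 1 to compound 4 (0.25 log units; that floor lies within the scatter), is only a floor. So far, this position shows no measured difference with or without that carbonyl.

From the compounds shown here alone, whether a hydrogen, an amine or a carboxylic acid on the sulfur would give a measured number remains open.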